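Chalcone cytotoxicity: methyl replacing bromo on the ketone ring

This account rests on a few compounds, and the source may have more. Where it says the series, first, only, none or still open, it means among the compounds named here.

This account follows two bromochalcones and one analogue in an ADME assay on MCF-10A cells (Homo sapiens) for cytotoxicity, read by sulforhodamine B assay, with a stated time of 72 h, tested at 10 uM; a lower number here means a weaker effect, a higher number a stronger effect of the compound at the concentration tested. Compound 1 `COc1cc(Br)cc(/C=C/C(=O)c2ccc(C)cc2)c1O` gives 155% in this assay, while compound 2 `O=C(/C=C/c1cc(Br)ccc1O)c1ccc(Br)cc1` gives 32.8%. Compound 2 therefore stands at the lowest of the two numbers, and the gap to compound 1 lies well beyond the scatter. Compound 3 `Cc1ccc(C(=O)/C=C/c2cc(Br)ccc2O)cc1` has not yet been measured in this assay. It differs from compound 2 only in one place: methyl in place of bromo on an aromatic carbon. Among the compounds with values here, the same methyl-bearing ketone ring is found in compound 1, whose 155% is the higher of the two values, but compound 1 also differs from compound 3 elsewhere, so no single-change step supports a firm prediction. Compound 3 is estimated at 70%, within 20% to 150%, and the step of a number 37.2 percentage points higher from compound 2 to compound 3 (beyond the scatter) is expected to be an increase beyond the scatter, though with wide uncertainty.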

Compound 3, a percentage reported as activity, at one concentration (the size of the read-out at that concentration, not a potency): 32.4%
Compound 3: the middle estimate sits 37.6 percentage points above what was measured, and the stated range covers the measured number.
By their numbers in this assay, from the lowest: compounds 3 and 2 (each within the scatter of the next); then compound 1.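

In this assay, methyl in place of bromo on this aromatic carbon, para to a large group, gives a number 0.4 percentage points lower from compound 2 to compound 3 (within the scatter), so at this position the two groups are not told apart. The large difference lies with the other change: hydrogen in place of methoxy on an aromatic carbon gives a number 122.6 percentage points lower from compound 1 to compound 3 (beyond the scatter), which ties the high reading of compound 1 to its methoxy rather than to the methyl it shares with compound 3. Nothing available explains either result.

The compounds shown leave open whether an amine or a carboxylic acid at the position of the bromo and methyl would also leave the reading unchanged. They also leave open whether the methoxy step would be as large with bromo in place of methyl, or whether an ethoxy would act like the methoxy.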